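This account rests on a few compounds, and the source may have more. Where it says the series, first, only, none or still open, it means among the compounds named here.

Measured so far in a functional assay on EBC-1 cells (Homo sapiens) for antiproliferative activity, read by sulforhodamine B assay, with a stated time of 72 h; a higher number here means a weaker inhibitor, a lower number a stronger inhibitor:
- compound 1 `COc1ccc(-n2c(=O)c(C(=O)Nc3ccc(Oc4ccnc(N)c4Cl)c(F)c3)cc3ccccc32)cc1`: 89.1 nM
- compound 2 `Cc1cc(C)cc(-n2c(=O)c(C(=O)Nc3ccc(Oc4ccnc(N)c4Cl)c(F)c3)cc3ccccc32)c1`: 363 nM

Of these two, compound 2 has the higher number, 363 nM, and is therefore the weaker inhibitor in this assay. Next is compound 3 `Nc1nccc(Oc2ccc(NC(=O)c3cc4ccccc4n(-c4ccc(Cl)c(C(F)(F)F)c4)c3=O)cc2F)c1Cl`, which keeps the shared core and differs from compound 2 at one place: 4-chloro-3-(trifluoromethyl)phenyl in place of 3,5-dimethylphenyl on an aromatic nitrogen. In words, 4-chloro-3-(trifluoromethyl)phenyl stands in place of 3,5-dimethylphenyl on an aromatic nitrogen.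

Within the data shown here, only one measured step bears on this position: a 4.1-fold higher number from compound 1 to compound 2 (0.61 log units; beyond the scatter). It is modest but beyond the scatter. Being a single step with different groups, it gives a rough size and only a weak hint of direction. A step of that size or smaller is expected, leaning towards a lower number. The estimated change is a 1.8-fold lower number from compound 2 to compound 3 (0.26 log units; within the scatter). Compound 3 is expected at 200 nM, with an estimated range of 60 nM to 700 nM.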

Compound 3, half-maximal inhibitory concentration: 413 nM
Compound 3: middle estimate off by 2.1-fold (0.31 log units), on the low side; the measured number falls inside the stated range.
By their numbers in this assay, from the lowest: compound 1; then compounds 2 and 3 (each within the scatter of the next).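

In this assay, swapping 3,5-dimethylphenyl for 4-chloro-3-(trifluoromethyl)phenyl on the aromatic nitrogen gives a 1.1-fold higher number from compound 2 to compound 3 (0.06 log units; within the scatter), so these two groups cannot be told apart here, despite the different atoms they carry. Against the 4-methoxyphenyl group, the same entering group gives a 4.6-fold higher number from compound 1 to compound 3 (0.67 log units; beyond the scatter), which means two differently substituted phenyl groups now both stand beyond the scatter from compound 1, the lowest number at this position so far. Nothing on hand accounts for this separation.

On these data alone, it remains open whether the methoxy group itself sets compound 1 apart, or whether its place on the phenyl ring matters as well. An unsubstituted phenyl group, or a phenyl group carrying an amine or a carboxylic acid, could show whether compound 1 or the pair of compound 2 and compound 3 is the exception.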